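The compounds below may be only part of what the source reports. "The series", "measured", "known", "first", "only" and "open" are said of these compounds alone.

The measured compounds, all read in a functional assay with Alpha-1A adrenergic receptor (Homo sapiens) as the target, read by calcium flux; on this read-out lower numbers stand for smaller maximal responses and higher numbers for larger maximal responses:

Compound 1, `CC(C)n1nccc1-c1ccccc1NCC1=NCCN1`: compound 1 gives 0%.
Compound 2, `CCn1ccc(-c2ccccc2NCC2=NCCN2)n1`: compound 2 gives 78%.
Compound 3, `c1ccc(-c2cn[nH]c2)c(NCC2=NCCN2)c1`: compound 3 gives 112%.

Compound 1 stands lowest of the three. Its nearest neighbour in value is compound 2, which sits far above it, beyond the scatter, and compound 3 sits further above still, also beyond the scatter. Within the data shown here, no pair among the three measured compounds differs in only one place, so no single step can be read off directly; the three values simply show that compound 1 produces no measurable maximal response where compound 2 and compound 3 produce large ones.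

The next compound is compound 4, `CCCn1nccc1-c1ccccc1NCC1=NCCN1`. Compared with compound 1 the change is propyl in place of isopropyl on an aromatic nitrogen. Among the measured compounds shown here, nothing among the measured compounds isolates this kind of change, so the size of the step is uncertain. With compound 1 giving 0%, a move in this assay can only go upward or stay flat. The step is expected to be a number 20 percentage points higher from compound 1 to compound 4 (beyond the scatter), small and likely within or just beyond the scatter. Compound 4 is therefore estimated at 20%, between 0% and 65%.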

Compound 4, largest response reached (reported as maximal response), in percent of the reference or control that the assay uses: 59%
For compound 4 the middle estimate is 39 percentage points below the measured one; the range from low to high includes it.
By their numbers in this assay, from the lowest: compound 1; then compound 4; then compound 2; then compound 3.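

In this assay, rearranging the same three carbons from isopropyl to propyl on the aromatic nitrogen gives a number 59 percentage points higher from compound 1 to compound 4 (beyond the scatter), so this position is sensitive to how its chain is joined, not only to how many carbons it carries. The absence of response in compound 1 therefore does not extend to every three-carbon group at this place, since compound 4 gives 59% on the same core. Nothing shown here gives a reason for the difference between isopropyl and propyl.

On these data alone, it remains open whether a longer chain such as butyl, or a small ring such as cyclopropyl, on this nitrogen would raise or lower the response. Compound 2 and compound 3 differ from compound 4 in more than one place, so the compounds shown do not settle what a smaller group would do here.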